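The source may hold more compounds than are shown below. What is called first, only, known or untested is meant among the compounds shown, and "the series" means these compounds.

Measured so far:
- compound 1, `CC(C)(C)c1ccc(C(=O)N2CCC3(CC2)C(=O)N(CC(=O)NCCCCCNS(C)(=O)=O)CN3c2ccccc2)cc1`: 5500 nM
- compound 2, `CC(C)(C)OC(=O)N1CCN(C(=O)CN2CN(c3ccccc3)C3(CCN(C(=O)c4ccc(C5CCCCC5)cc4)CC3)C2=O)CC1`: 3500 nM

Both values come from an assay on HEK293 cells for displacement of a labelled ligand from NPC1-like intracellular cholesterol transporter 1 (Homo sapiens); a higher number here means a weaker inhibitor, a lower number a stronger inhibitor. Compound 1 gives 5500 nM and compound 2 gives 3500 nM; the two numbers lie within the scatter of each other, so nothing separates compound 1 from compound 2 on the evidence so far. For the measured compounds named here, compound 2 differs from compound 1 in more than one place, so no single step is read out of that pair.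

The next compound, compound 3, `CC(C)(C)c1ccc(C(=O)N2CCC3(CC2)C(=O)N(CC(=O)NCCCCCO)CN3c2ccccc2)cc1`, is the single-point variant of compound 1. The change is hydroxy in place of methanesulfonamido on a saturated chain carbon, five bonds along the chain from an amide-type nitrogen. The chain itself and everything between it and the shared core stay as in compound 1. Going by the values given here, no step of this kind has yet been measured, so the expectation rests only on the value of compound 1 and on the nature of the change, which sits at the far end of the chain, five bonds along from an amide-type nitrogen. In this assay no step beyond the scatter is expected for this exchange, a small rise in the number if anything. Compound 3 is therefore estimated at 6500 nM, with a range of 2500 nM to 17000 nM. This estimate corresponds to a step of a 1.2-fold higher number from compound 1 to compound 3 (0.07 log units; within the scatter).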

Compound 3, half-maximal inhibitory concentration: 9400 nM
Compound 3: middle estimate off by 1.4-fold (0.16 log units), on the low side; the measured number falls inside the stated range.
By their numbers in this assay, from the lowest: compounds 2, 1 and 3 (each within the scatter of the next, the first and the last beyond it).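

Working notes on the chain end: in this assay, hydroxy in place of methanesulfonamido on a saturated chain carbon, five bonds along the chain from an amide-type nitrogen, gives a 1.7-fold higher number from compound 1 to compound 3 (0.23 log units; within the scatter), the first single-point reading at this position in the series. On this one pair, the methanesulfonamido group, with its 5 heavy atoms and 2 double bonds, can give way to hydroxy, with 1 heavy atom, without a step beyond the scatter, so the sulfur-bearing part of the group is not shown to matter for the number here. No supporting measurement is available that would account for this reading.

Open, on these data alone, is whether an amine or a carboxylic acid at the end of this chain, or a longer chain carrying hydroxy, would give a step beyond the scatter. Also open, as far as these compounds go, is whether the same exchange reads alike when the tert-butyl group of compound 1 and compound 3 is replaced by cyclohexyl, the group carried by compound 2.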